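The source may hold more compounds than are shown below. What is called first, only, known or untested is meant among the compounds shown, and "the series" means these compounds.

Within the data shown here, in a functional assay on QG-56 cells (Homo sapiens) for cytotoxicity, read by MTT assay, with a stated time of 48 h (a higher number here means a weaker inhibitor, a lower number a stronger inhibitor), compound 1 `COc1cc(/C=C/C(=O)C2=C(/C=C/c3ccc(O)c(OC)c3)NC(=O)NC2c2ccccc2)ccc1O` gives 50000 nM, while compound 2 `COc1cc(/C=C/C(=O)C2=C(/C=C/c3ccc(O)c(OC)c3)NC(=O)NC2c2ccc(N(C)C)cc2)ccc1O` gives 12500 nM, the lower of the two numbers so far. Compound 3 `COc1cc(/C=C/C(=O)C2=C(/C=C/c3ccc(O)c(OC)c3)NC(=O)NC2c2cccc([N+](=O)[O-])c2)ccc1O` has not yet been measured. Its change from compound 2 is 3-nitrophenyl in place of 4-(dimethylamino)phenyl on a saturated ring carbon. Among the measured compounds shown here, compound 3 carries no dimethylamino group, so it is expected to give back part of the one measured step that bears on this, a 4.0-fold lower number from compound 1 to compound 2 (0.60 log units; beyond the scatter), a modest step that came with dimethylamino in place of hydrogen on an aromatic carbon. For the measured compounds named here, no measured compound carries 3-nitrophenyl, so the expectation remains loose. The expected move is modest and towards a higher number, estimated as a 2.0-fold higher number from compound 2 to compound 3 (0.30 log units; within the scatter). The estimate for compound 3 is 25000 nM, with an expected range from 9000 nM to 60000 nM.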

Compound 3, half-maximal inhibitory concentration: 25000 nM
Compound 3: middle estimate and measured number agree at the digits printed; the range from low to high includes it.
By their numbers in this assay, from the lowest: compounds 2, 3 and 1 (each within the scatter of the next, the first and the last beyond it).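

In this assay, 3-nitrophenyl in place of 4-(dimethylamino)phenyl on the saturated ring carbon gives a 2.0-fold higher number from compound 2 to compound 3 (0.30 log units; within the scatter) and so cannot be told apart from the dimethylamino compound. Nitro in place of hydrogen on an aromatic carbon gives a 2.0-fold lower number from compound 1 to compound 3 (0.30 log units; within the scatter) and likewise cannot be told apart from the unsubstituted phenyl compound, so compound 3 sits within the scatter of both neighbours, although compound 1 and compound 2 themselves differ by more than the scatter. Nothing measured here offers a reason for these readings.

A carboxylic acid or a primary amine on this phenyl ring could test whether any substituent there moves the number further than these two do. On these data alone, it also remains open whether a longer alkyl chain in place of the phenyl ring would be tolerated at this position.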